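This account rests on a few compounds, and the source may have more. Where it says the series, first, only, none or still open, it means among the compounds named here.

Measured so far:
compound 1, `O=C1NC(=O)/C(=C\c2ccc(OCC(=O)N3N=C(c4ccccc4)CC3c3ccc(C(F)(F)F)cc3)cc2)S1`: 1000 nM in an assay on cells for inhibition of histone deacetylase 4 (Homo sapiens), read by fluorescence, with a stated time of 30 min; a lower number here means a stronger inhibitor, a higher number a weaker inhibitor
compound 2, `O=C1NC(=O)/C(=C\c2ccc(OCC(=O)N3N=C(c4ccccc4)CC3c3ccc(Br)cc3)cc2)S1`: 1200 nM

Compound 1 holds the lower of the two numbers in this assay, but with a 1.2-fold higher number from compound 1 to compound 2 (0.08 log units; within the scatter) the two compounds are not separated. Compound 3, `O=C1NC(=O)/C(=C\c2ccc(OCC(=O)N3N=C(c4ccc(F)cc4)CC3c3ccc(C(F)(F)F)cc3)cc2)S1`, differs from compound 1 by fluoro in place of hydrogen on an aromatic carbon. No measured step covers this change; the one step shown, a swap of one aromatic substituent for another, stayed within the scatter. A step beyond the scatter in this assay is therefore not expected. Compound 3 is expected at 1000 nM. The expected range for compound 3 runs from 500 nM to 2000 nM. Expected step: no change at the digits printed from compound 1 to compound 3 (within the scatter).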

Compound 3, half-maximal inhibitory concentration: 1300 nM
For compound 3 the middle estimate is 1.3-fold (0.11 log units) below the measured one; measured number inside the range.
By their numbers in this assay, from the lowest: compounds 1, 2 and 3 (each within the scatter of the next).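

Phenyl to 4-fluorophenyl in this assay gives a 1.3-fold higher number from compound 1 to compound 3 (0.11 log units; within the scatter), so compound 3 is not separated from compound 1. For the compounds shown here, this is the first reading on the ring that carries no substituent in compound 1, whereas the earlier step, bromo in place of trifluoromethyl, concerned the other aromatic ring. No supporting data bear on this result. A single fluoro leaves this place only lightly probed. On these data alone, whether an amine, a carboxylic acid or a methoxy group at the same place would separate from compound 1 remains open.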